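Ester to acid on the nitro compound

This account rests on a few compounds, and the source may have more. Where it says the series, first, only, none or still open, it means among the compounds named here.

Values in a functional assay on HT-1080 cells (Homo sapiens) for antiproliferative activity, read by MTT assay, with a stated time of 72 h; on this read-out higher numbers stand for weaker inhibition and lower numbers for stronger inhibition:
- compound 1 `CCOC(=O)c1cc(-c2ccc(OC)c([N+](=O)[O-])c2)c(-c2cc(OC)c(OC)c(OC)c2)s1`: 26100 nM
- compound 2 `CCOC(=O)c1cc(-c2ccc(OC)c(O)c2)c(-c2cc(OC)c(OC)c(OC)c2)s1`: 82600 nM

Of the two measured compounds, compound 1 stands lowest, at 26100 nM in this assay. Among the measured compounds shown here, the only measured step is a 3.2-fold higher number from compound 1 to compound 2 (0.50 log units; beyond the scatter), with hydroxy in place of nitro on an aromatic carbon. It is modest but beyond the scatter.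

The next compound is compound 3 `COc1ccc(-c2cc(C(=O)O)sc2-c2cc(OC)c(OC)c(OC)c2)cc1[N+](=O)[O-]`. The change is hydrogen in place of ethyl on an oxygen next to a carbonyl group, which also reads as ethoxycarbonyl to carboxy. For the measured compounds named here, no measured pair differs at this place, so the data give no direct size for this change. Going by the values given here, the step of a 3.2-fold higher number from compound 1 to compound 2 (0.50 log units; beyond the scatter) is the only guide, and an indirect one, as it shows how far a single change on the core of compound 1 moved the number. A step of similar modest size is therefore expected in this assay, towards a higher number, with wide uncertainty on both size and direction. The expected step is a 2.3-fold higher number from compound 1 to compound 3 (0.36 log units; beyond the scatter). For compound 3 the estimated value is 60000 nM, with an estimated range of 20000 nM to 180000 nM.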

Compound 3, half-maximal inhibitory concentration: 38100 nM
Beside the measured number, compound 3's estimate is 1.6-fold (0.20 log units) above it; the range from low to high includes it.
By their numbers in this assay, from the lowest: compounds 1 and 3 (each within the scatter of the next); then compound 2.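

Working from this assay, the ester position now has its first direct reading: the change from ethoxycarbonyl to carboxy gives a 1.5-fold higher number from compound 1 to compound 3 (0.16 log units; within the scatter). On this read-out, the ethyl ester and the free carboxylic acid cannot be told apart while the nitro group stays in place, whereas the swap of nitro for hydroxy gave a 3.2-fold higher number from compound 1 to compound 2 (0.50 log units; beyond the scatter). The compounds shown therefore place one change within the scatter and the other beyond it, though each rests on a single pair, and no available data give a reason for this result.

As far as these compounds go, whether the same holds beyond the ethyl ester remains open: a methyl ester, a longer chain such as a butyl ester, or a primary amide in place of the carboxy group could each read differently. From the compounds shown here alone, it is also open whether the ethoxycarbonyl to carboxy change would stay within the scatter on the hydroxy compound, as the pair now in hand carries the nitro group, and whether an amine at that aromatic carbon would fall with nitro or with hydroxy.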